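Amide side chain swap: compound 3 to compound 4

The source may report more compounds than this note shows. Statements on the series, on what has been measured and on what is new or still open speak of the compounds shown alone.

Among the measured compounds shown here, in a physicochemical assay for solubility, at pH 6.8 (a lower number here means a less soluble compound, a higher number a more soluble compound), compound 3, `CN(C)Cc1ccc(-c2cnc(N)c(C(=O)NC[C@@](C)(O)C(F)(F)F)n2)cc1`, gives 510000 nM, the only actual number in this small set. Compound 1, `Nc1ncc(-c2ccc(CN3CCC(N4CCCC4)CC3)cc2)nc1C(=O)N[C@H]1CC[C@H](O)CC1`, reads > 1000000 nM; > 1000000 nM (2 entries), which is a limit of the assay and not a number. Compound 2, `CCN(CC)C1CCN(Cc2ccc(-c3cnc(N)c(C(=O)N[C@H]4CC[C@H](O)CC4)n3)cc2)CC1`, reads > 1000000 nM, which is also a limit. Compound 3 is therefore the sole quantified reference point for the next comparison.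

Compound 4, `CN(C)Cc1ccc(-c2cnc(N)c(C(=O)NC3CCCCC3)n2)cc1`, carries cyclohexyl in place of 2-hydroxy-2-(trifluoromethyl)propyl on an amide-type nitrogen. The counted difference is cyclohexyl in place of 2-hydroxy-2-(trifluoromethyl)propyl on an amide-type nitrogen.

For the measured compounds named here, no pair of measured compounds here differs in a single place, so no direct precedent sizes this change. A downward move in this assay, beyond the usual scatter but of moderate size, is expected. The estimated step is a 3.4-fold lower number from compound 3 to compound 4 (0.53 log units; beyond the scatter). Compound 4 is expected to read about 150000 nM, with an estimated range of 30000 nM to 600000 nM.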

Compound 4, solubility: 190000 nM
Compound 4: the middle estimate sits 1.3-fold (0.10 log units) below what was measured; the measured number falls inside the stated range.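

In this assay, the amide side chain now has its first readable single-place step in the series, with a 2.7-fold lower number from compound 3 to compound 4 (0.43 log units; beyond the scatter) for cyclohexyl in place of 2-hydroxy-2-(trifluoromethyl)propyl on an amide-type nitrogen. This modest step goes with the loss of the hydrogen-bond donor, the hydrogen-bond acceptor, the fluorine and the defined stereocentre counted on the outgoing side chain, and with the arrival of a ring of carbon only. Neither compound of this pair sits at the limit of the assay, which stands as follows: the limit of > 1000000 nM in this assay, at which 1 of the 4 values shown sits.

Which part of the outgoing side chain accounts for the step remains unresolved, as the swap changes all of these features at once. Also open, going by these compounds, is where compound 4 would move with an amine or a carboxylic acid on the cyclohexyl ring.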